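The source may hold more compounds than are shown below. What is called first, only, known or untested is meant among the compounds shown, and "the series" means these compounds.

In an ADME assay on HeLa cells (Homo sapiens) for cytotoxicity, read by ATP content, with a stated time of 3 days (on this read-out higher numbers stand for lower toxicity in this test and lower numbers for higher toxicity in this test), compound 2 (`O=c1n(Cc2cc3cnccc3n2CCCCO)c2cnccc2n1C1CC1`) gives > 100000 nM, which is a limit of the assay and not a number. Its close relative, compound 1 (`O=c1n(Cc2cc3cnccc3n2CCCCF)c2cnccc2n1C1CC1`), gives > 50000 nM, which is also a limit. The two compounds share a core and differ only at the end of the chain, where hydroxy stands in place of fluoro. Compound 3 (`CS(=O)(=O)CCCn1c(Cn2c(=O)n(C3CC3)c3ccncc32)cc2cnccc21`) has not yet been measured. It departs from compound 2 at the same chain: methylsulfonyl in place of hydroxymethyl on a saturated chain carbon, three bonds along the chain from an aromatic nitrogen. Here methylsulfonyl takes the place of hydroxymethyl, so 4-hydroxybutyl becomes 3-(methylsulfonyl)propyl.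

Within the data shown here, only one measured step bears on this change, and it is a step that the two limits leave unreadable from compound 1 to compound 2. It therefore offers no size to carry over. Neither chain end tested so far has produced a number in this assay, so no step beyond the usual scatter is expected, in either direction. This expectation rests on compound 2, whose limit is > 100000 nM. The expected change is a number no higher from compound 2 to compound 3 (the limit leaves the size open). For compound 3 the estimate is 100000 nM, with an expected range from 40000 nM to 200000 nM, and the assay may well report only a limit again.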

Compound 3, half-maximal cytotoxic concentration: > 50000 nM
Compound 3 ended at the assay's limit; the forecaster's own chance of this, stated with the estimate: 85%; the middle value lies beyond the limit too.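

In this assay, compound 1, compound 2 and compound 3 each give a limit and not a number, so the steps among them cannot be read. The compounds shown leave open whether the fluoro, hydroxy and methylsulfonyl chain ends differ at all in half-maximal cytotoxic concentration.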